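From 3,5-dichlorophenyl to pyridin-2-yl on a shared core

The source may report more compounds than this note shows. Statements on the series, on what has been measured and on what is new or still open speak of the compounds shown alone.

Of the compounds shown here, three with the same core have been measured so far in a functional assay on BXPC-3 cells (Homo sapiens) for cytotoxicity, read by MTT assay, with a stated time of 72 h; a higher number here means a weaker inhibitor, a lower number a stronger inhibitor. Compound 1 (`O=C1C(Nc2ccc(-c3ccc(Cl)cc3)cc2)=CC(=O)c2ncncc21`) gives 10100 nM, compound 2 (`CN1CCN(c2ccc(NC3=CC(=O)c4ncncc4C3=O)cc2)CC1`) gives 900 nM, and compound 3 (`O=C1C(Nc2ccc(-c3cc(Cl)cc(Cl)c3)cc2)=CC(=O)c2ncncc21`) gives 3300 nM. Compound 3 thus holds the middle place of the three numbers, and its distance from each of the others is beyond the usual scatter.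

The next compound is compound 4 (`O=C1C(Nc2ccc(-c3ccccn3)cc2)=CC(=O)c2ncncc21`), in which pyridin-2-yl stands in place of 3,5-dichlorophenyl on an aromatic carbon: pyridin-2-yl in place of 3,5-dichlorophenyl on an aromatic carbon.

All three measured steps change this same group. Exchanging 4-chlorophenyl for 3,5-dichlorophenyl gives a 3.1-fold lower number from compound 1 to compound 3 (0.49 log units; beyond the scatter), a modest step. Exchanging 4-chlorophenyl for 4-methylpiperazin-1-yl gives an 11-fold lower number from compound 1 to compound 2 (1.05 log units; beyond the scatter), a large one, and the remaining exchange gives a 3.7-fold higher number from compound 2 to compound 3 (0.56 log units; beyond the scatter), again modest. So this group clearly matters in this assay, yet no measured compound carries pyridin-2-yl, and the data do not settle a direction. A step beyond the scatter is therefore not expected, though a modest one in either direction would be no surprise.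

The estimate amounts to a 1.2-fold lower number from compound 3 to compound 4 (0.07 log units; within the scatter), an expected change that is small. For compound 4 the expected value is about 2800 nM, within an estimated range of 900 nM to 9000 nM.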

Compound 4, half-maximal inhibitory concentration: 2700 nM
Beside the measured number, compound 4's estimate is 1.0-fold (0.02 log units) above it; the range from low to high includes it.
By their numbers in this assay, from the lowest: compound 2; then compounds 4 and 3 (each within the scatter of the next); then compound 1.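

In this assay, exchanging 3,5-dichlorophenyl for pyridin-2-yl gives a 1.2-fold lower number from compound 3 to compound 4 (0.09 log units; within the scatter) and so leaves the number effectively unchanged. This position, para to a large group, can therefore take two quite different aromatic rings with no measurable difference: one has two chlorines and no hydrogen-bond acceptor, the other has no chlorine and a ring nitrogen counted as an acceptor. The other comparisons place pyridin-2-yl relative to the remaining groups, with a 3.0-fold higher number from compound 2 to compound 4 (0.48 log units; beyond the scatter) showing that it does not match 4-methylpiperazin-1-yl and a 3.7-fold lower number from compound 1 to compound 4 (0.57 log units; beyond the scatter) showing that it clearly differs from 4-chlorophenyl, so chlorine on this ring is not needed to reach the level of compound 3.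

Going by these compounds, it remains open whether a different pyridine attachment, such as pyridin-3-yl, or a simpler amine, such as morpholine or dimethylamino, would behave like pyridin-2-yl or like 4-methylpiperazin-1-yl. Nothing available here explains why these groups differ or why two of them give such similar numbers.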